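Removing One Fluorine from a Serotonin Receptor Ligand

The source may hold more compounds than are shown below. What is called first, only, known or untested is meant among the compounds shown, and "the series" means these compounds.

Compound 2 `CCC1(CCCCN2CCN(c3ccc(F)cc3)CC2)C(=O)Nc2ccc(F)cc21` carries two fluoro groups, and in an assay on CHO cells for displacement of a labelled ligand from 5-hydroxytryptamine receptor 7 (Homo sapiens) (a higher number here means a weaker inhibitor, a lower number a stronger inhibitor), compound 2 gives 1.5 nM. Compound 1 `CCC1(CCCCN2CCN(c3ccccc3)CC2)C(=O)Nc2ccccc21` has no fluoro at all, and in this assay compound 1 gives 2.07 nM; compound 2 shows the lowest of these two numbers, yet the gap to compound 1 lies within the scatter. Compound 3 `CCC1(CCCCN2CCN(c3ccc(F)cc3)CC2)C(=O)Nc2ccccc21` keeps one fluoro and drops the other: hydrogen in place of fluoro on an aromatic carbon. Going by the values given here, no measured step of this kind exists here, so only a small shift in this assay is expected, and compound 3 is estimated at 1.8 nM (range 0.8 nM to 4 nM), a step of a 1.2-fold higher number from compound 2 to compound 3 (0.08 log units; within the scatter) expected to stay within the scatter.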

Compound 3, inhibition constant: 0.43 nM
Compound 3: middle estimate off by 4.2-fold (0.62 log units), on the high side; the measured number lies below the stated range.
By their numbers in this assay, from the lowest: compound 3; then compounds 2 and 1 (each within the scatter of the next).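

Hydrogen in place of fluoro on the six-membered aromatic ring of the fused system gives a 3.5-fold lower number from compound 2 to compound 3 (0.54 log units; beyond the scatter) in this assay, so this position is sensitive to the change. Fluoro in place of hydrogen at the other fluoro site gives a 4.8-fold lower number from compound 1 to compound 3 (0.68 log units; beyond the scatter), so the two fluoro groups push the number in opposite directions, a split hidden by the close values of compound 1 and compound 2.

Nothing shown here explains this difference. On these data alone, whether chloro or methoxy at the fused-system position would behave more like hydrogen or like fluoro remains open.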